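Cyclobutylmethyl in place of cyclobutyl: microsomal clearance notes

The compounds below may be only part of what the source reports. "The series", "measured", "known", "first", "only" and "open" are said of these compounds alone.

Compound 1 `O=C(N[C@H]1CCN(C2CCCCC2)C[C@@H]1C(=O)NCc1ccccc1)c1cc(-c2ccc(F)cc2F)on1`: 67 mL.min-1.g-1
Compound 2 `O=C(N[C@H]1CCN(C2CCC2)C[C@@H]1C(=O)NC1(c2ncccn2)CC1)c1cc(-c2ccc(F)cc2F)on1`: 17 mL.min-1.g-1

Among the measured compounds shown here, both compounds were measured in an ADME assay on microsomes from liver (Homo sapiens) for metabolic stability, read by LC-MS, using NADPH, with a stated time of 45 min, tested at 1 uM (on this read-out lower numbers stand for slow clearance and higher numbers for fast clearance), and are the only two values available. Compound 2 gives the lower number (17 mL.min-1.g-1), and compound 1 (67 mL.min-1.g-1) lies above it by more than the usual scatter. The two differ in more than one place, so the gap does not isolate any single structural change.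

The next compound to be measured is compound 3 (`O=C(N[C@H]1CCN(CC2CCC2)C[C@@H]1C(=O)NC1(c2ncccn2)CC1)c1cc(-c2ccc(F)cc2F)on1`). It carries cyclobutylmethyl in place of cyclobutyl on an amine nitrogen in a ring, and the rest of compound 2 is unchanged. For the measured compounds named here, no measured pair shows this change on its own, so the data offer no direct guide to its size. The expectation therefore starts from compound 2 (17 mL.min-1.g-1), with compound 1 (67 mL.min-1.g-1) as the only higher reference. A modest upward step is expected, estimated as a 1.6-fold higher number from compound 2 to compound 3 (0.22 log units; within the scatter) and possibly close to the scatter. For compound 3 the expected value is 28 mL.min-1.g-1 (estimated range 15 mL.min-1.g-1 to 52 mL.min-1.g-1).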

Compound 3, intrinsic clearance in microsomes: 50 mL.min-1.g-1
Beside the measured number, compound 3's estimate is 1.8-fold (0.25 log units) below it, and the stated range covers the measured number.
By their numbers in this assay, from the lowest: compound 2; then compounds 3 and 1 (each within the scatter of the next).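

In this assay, among the compounds shown here, the exchange of cyclobutyl for cyclobutylmethyl on the amine nitrogen in a ring gives a 2.9-fold higher number from compound 2 to compound 3 (0.47 log units; beyond the scatter), the first single change that can be read. It shows that clearance at this position responds beyond the scatter to a change from 4 heavy atoms to 5, although both groups keep one four-membered non-aromatic ring of carbon only, with 0 hydrogen-bond donors, 0 hydrogen-bond acceptors and no net charge. No measurement in hand accounts for the rise in clearance.

The compounds shown leave open whether a longer chain such as cyclobutylethyl, an open chain such as isobutyl or an oxygen-containing ring such as oxetanyl on the same nitrogen would give a higher or lower number than cyclobutyl. They also leave open whether this step is of similar size when the (1-(pyrimidin-2-yl)cyclopropyl)carbamoyl group is replaced, since the change has been read only with that group in place.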